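The source may hold more compounds than are shown below. What is called first, only, known or untested is meant among the compounds shown, and "the series" means these compounds.

Among the measured compounds shown here, compound 2 `CC(C)C[C@H](N)c1cc(C(F)(F)F)ccc1N1CCN(C(=O)C(C)Cc2ccc(Cl)cc2)CC1` gives 47 nM in an assay on HEK293 cells for displacement of a labelled ligand from Melanocortin receptor 4 (Homo sapiens) (a lower number here means a stronger inhibitor, a higher number a weaker inhibitor), and stands lowest of the two numbers measured so far; compound 1 `COc1cc(CC(C)C(=O)N2CCN(c3ccc(C(F)(F)F)cc3[C@@H](N)CC(C)C)CC2)ccc1Cl` gives 230 nM in this assay, and the one measured step is a 4.9-fold lower number from compound 1 to compound 2 (0.69 log units; beyond the scatter). Compound 3 `CC(C)C[C@H](N)c1cc(C(F)(F)F)ccc1N1CCN(C(=O)CC(C)C(=O)c2ccc(Cl)cc2)CC1` differs from compound 2 by 2-((4-chlorophenyl)carbonyl)propyl in place of 1-(4-chlorobenzyl)ethyl on a carbonyl carbon. For the measured compounds named here, the single measured step concerns a group on an aromatic ring, not the chain on the carbonyl, so no measured step bears on this change. With no direct guide, a somewhat higher number is expected, and compound 3 is estimated at 150 nM (range 40 nM to 600 nM). The expected step is a 3.2-fold higher number from compound 2 to compound 3 (0.50 log units; beyond the scatter).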

Compound 3, inhibition constant: 1100 nM
The estimate for compound 3 lay 7.3-fold (0.87 log units) below the measured number; measured number outside the range, above it.
By their numbers in this assay, from the lowest: compound 2; then compound 1; then compound 3.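

In this assay, the chain on the carbonyl carbon proves highly sensitive: 2-((4-chlorophenyl)carbonyl)propyl in place of 1-(4-chlorobenzyl)ethyl gives a 23-fold higher number from compound 2 to compound 3 (1.37 log units; beyond the scatter), a large step. Set against the methoxy-bearing chain, the same entering group gives a 4.8-fold higher number from compound 1 to compound 3 (0.68 log units; beyond the scatter), so it also ranks behind that weaker chain. Nothing available explains why this change costs so much.

The compounds shown do not separate the added carbonyl in the chain from the chain's altered shape. A matching chain with a hydroxyl or an amine in place of that carbonyl would help tell these apart.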